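A few compounds are considered here, and "the series" means these few. Any claim that something is new, unique, unknown or untested is made for them only; others in the source may bear on it.

Compound 1 `CC(C)c1ccccc1-c1ccc2[nH]ncc2c1` carries an isopropyl group on the outer ring of a shared core. In an assay on CHO-TREX cells for antagonist activity at transient receptor potential cation channel subfamily A member 1 (Homo sapiens), read by FLIPR and calcium flux, with a stated time of 10 min (on this read-out higher numbers stand for weaker inhibition and lower numbers for stronger inhibition), compound 1 gives 514 nM. Compound 2 `CC(C)(C)c1ccccc1-c1ccc2[nH]ncc2c1` differs from it only by methyl in place of hydrogen on a saturated chain carbon bound to an aromatic carbon and two saturated chain carbons, and in this assay compound 2 gives 3400 nM. That single added carbon produced a 6.6-fold higher number from compound 1 to compound 2 (0.82 log units; beyond the scatter), so the larger group here weakened the compound.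

Compound 3 `COc1cc2[nH]ncc2cc1-c1ccccc1C(F)(F)F` has a different core, and the difference between the two cores is not broken down here. In this assay compound 3 gives 26 nM, the lowest number of the three measured compounds.

Compound 4 `CCOc1cc2[nH]ncc2cc1-c1ccccc1C(F)(F)F` is not yet measured. It differs from compound 3 by methyl in place of hydrogen on a saturated chain carbon bound to an oxygen on an aromatic ring. Within the data shown here, this is the same kind of change as the one between compound 1 and compound 2, but not the same: there the new methyl sat on a saturated chain carbon bound to an aromatic carbon and two saturated chain carbons, whereas here it sits on a saturated chain carbon bound to an oxygen on an aromatic ring. Because the earlier step was a 6.6-fold higher number from compound 1 to compound 2 (0.82 log units; beyond the scatter), some loss is expected, but a smaller one given the different surroundings; the expected step is a 2.1-fold higher number from compound 3 to compound 4 (0.33 log units; beyond the scatter). Compound 4 is estimated at 55 nM, between 15 nM and 200 nM.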

Compound 4, half-maximal inhibitory concentration: 39 nM
Compound 4: the middle estimate sits 1.4-fold (0.15 log units) above what was measured; the measured number falls inside the stated range.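

In this assay, methyl in place of hydrogen on a saturated chain carbon bound to an oxygen on an aromatic ring gives a 1.5-fold higher number from compound 3 to compound 4 (0.18 log units; within the scatter), so the change from methoxy to ethoxy leaves no measurable difference between these two compounds. A similar one-carbon addition on the core of compound 1 had a clear cost, so the size of the step did not carry over from one core to the other: the same change on two cores in this assay, a 6.6-fold higher number (0.82 log units; beyond the scatter) from compound 1 to compound 2 and a 1.5-fold higher number (0.18 log units; within the scatter) from compound 3 to compound 4, 4.4-fold (0.64 log units) apart, beyond the scatter of two such steps This does not show why the steps differ, since the added methyl also sits in a different place in each pair, and a single pair per core cannot separate the effect of the core from that of the immediate surroundings or give a rule for other cores.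

The compounds shown leave open whether a longer chain than ethoxy, or an amine in its place, would keep the number low on the core of compound 3. They also leave open how the change from methoxy to ethoxy would behave with isopropyl instead of trifluoromethyl on the outer ring.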